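Ester Chain Unsaturation in a Monoglyceride Lipase Series

The source may report more compounds than this note shows. Statements on the series, on what has been measured and on what is new or still open speak of the compounds shown alone.

Two esters with long fatty chains have been measured. In an assay on membranes from cerebellum for inhibition of Monoglyceride lipase (Rattus norvegicus), tested at 100 uM (a higher number here means more inhibition at the concentration tested (going by the name of the read-out), a lower number less inhibition), compound 1 `CCCCC/C=C\C/C=C\C/C=C\C/C=C\CCCC(=O)OC[C@H]1COC(C)(C)O1` gives 34%. In this assay compound 2 `CCCCCCCC/C=C\CCCCCCCC(=O)OCC1CCCCO1` gives 35%. On these two numbers compound 2 has the larger reading, but the two values lie within the scatter of each other, so no order between compound 1 and compound 2 can be stated. Both share a fatty ester on a cyclic alcohol, and both sit at moderate inhibition.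

Compound 3 `CCCCC/C=C\C/C=C\CCCCCCCC(=O)OCC1CCCCO1` has not yet been measured. It differs from compound 2 by the change (hept-1-en-1-yl in place of heptyl on a saturated chain carbon bound to a double-bonded chain carbon). Since compound 1, with more unsaturation in its chain, and compound 2 lie within the scatter of each other, no step beyond the scatter is expected in this assay for this change. The step from compound 2 to compound 3 is estimated at no change at the digits printed from compound 2 to compound 3 (within the scatter). For compound 3 the expected value is 35%, in the range 20% to 50%.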

Compound 3, a percentage reported as inhibition, at one concentration (the size of the read-out at that concentration, not a potency): 38%
Compound 3: middle estimate off by 3 percentage points, on the low side; the measured number falls inside the stated range.
By their numbers in this assay, from the lowest: compounds 1, 2 and 3 (each within the scatter of the next).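

In this assay, going by these compounds alone, hept-1-en-1-yl in place of heptyl on a saturated chain carbon bound to a double-bonded chain carbon gives a number 3 percentage points higher from compound 2 to compound 3 (within the scatter), the first step that can be read at a single place. With the cyclic alcohol part held constant, the added double bond in the chain does not carry the reading beyond the scatter, which the comparison of compound 1 with compound 2 could not show, as those two differ in more than one place. Nothing at hand explains the size of this step.

Compound 1 differs from compounds 2 and 3 in both chain and alcohol part, so neither contribution can be read alone. Going by these compounds, how a fully saturated chain, a shorter chain or an amide in place of the ester would read remains open.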